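This account rests on a few compounds, and the source may have more. Where it says the series, first, only, none or still open, it means among the compounds named here.

Compound 2 `CCOC(=O)c1cn(-c2ccc([N+](=O)[O-])cc2)nc1CC(C)C` is the starting point here. In a toxicity assay on HepG2 2.2.15 cells (Homo sapiens) for cytotoxicity, read by CCK-8 assay, with a stated time of 8 days (on this read-out higher numbers stand for lower toxicity in this test and lower numbers for higher toxicity in this test), compound 2 gives > 100000 nM, which is a limit of the assay and not a number. Two further compounds share its core: compound 1 `CC(C)Cc1nn(-c2nccs2)cc1C(=O)NCc1cccc(F)c1` and compound 3 `COc1ccc(CNC(=O)c2cn(-c3nccs3)nc2CC(C)C)cc1`. In this assay compound 1 gives > 100000 nM, again a limit. In this assay compound 3 gives > 100000 nM, also a limit. The step that the two limits leave unreadable from compound 1 to compound 3 cannot be read, so all that stands is the limit of > 100000 nM in this assay, at which 3 of the 3 values shown sit. Compound 4 `CCOC(=O)c1cn(-c2ccc(OC)cc2)nc1CC(C)C` differs from compound 2 by methoxy in place of nitro on an aromatic carbon. For the measured compounds named here, no measured step covers such a change, and since the limit of > 100000 nM in this assay, at which 3 of the 3 values shown sit, holds for every value, the step that the limit leaves unreadable from compound 2 to compound 4 is expected to be none beyond the scatter. Compound 4 is therefore estimated at 150000 nM, between 60000 nM and 400000 nM, most likely reported again as a limit.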

Compound 4, half-maximal cytotoxic concentration: 77100 nM
For compound 4 the middle estimate is 1.9-fold (0.29 log units) above the measured one; the measured number falls inside the stated range.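

In this assay, for the compounds shown here, compound 4 gives 77100 nM, the first value here that is a number, with methoxy on this aromatic carbon, para to a large group. Placing methoxy where nitro stood yields only a floor for the change, an at least 1.2-fold lower number from compound 2 to compound 4 (0.11 log units; that floor lies within the scatter). From the compounds shown here alone, that floor rests on a limit, so the true size of the change remains unknown.

Going by these compounds, what an amine, a hydroxyl or a longer ether chain would give on this carbon stays open. Most values shown give no number to compare against: the limit of > 100000 nM in this assay, at which 3 of the 4 values shown sit.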